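Moving a fluorine on a flat series of cytotoxic lactones

A few compounds are considered here, and "the series" means these few. Any claim that something is new, unique, unknown or untested is made for them only; others in the source may bear on it.

Compound 3 `O=C1OC[C@H](Cc2ccccc2)[C@H]1Cc1ccccc1F` is measured in a functional assay on HL-60 cells (Homo sapiens) for cytotoxicity, read by WST assay, with a stated time of 48 h (a lower number here means that less compound is needed, a higher number that more compound is needed for the effect), at 72000 nM. Compound 1 `COCOc1ccccc1C[C@H]1C(=O)OC[C@@H]1Cc1ccccc1` gives 76000 nM and compound 2 `CCCCCCCOc1ccccc1C[C@H]1C(=O)OC[C@@H]1Cc1ccccc1` gives 75000 nM; the steps of a 1.0-fold lower number from compound 1 to compound 2 (0.01 log units; within the scatter), a 1.1-fold lower number from compound 1 to compound 3 (0.02 log units; within the scatter) and a 1.0-fold lower number from compound 2 to compound 3 (0.02 log units; within the scatter) all stay within the scatter, so compound 3 shares the same level as the other two rather than standing apart. Compound 4 `O=C1OC[C@H](Cc2ccccc2)[C@H]1Cc1cccc(F)c1` differs from compound 3 in the ring that hangs off the core: 3-fluorophenyl in place of 2-fluorophenyl on a saturated chain carbon bound to a saturated ring carbon. Among the compounds with values here, no measured step changes this ring, so nothing directly bears on the move. Given that every measured change left this assay flat, compound 4 is expected to show no change at the digits printed from compound 3 to compound 4 (within the scatter) at most within the scatter, estimated at 72000 nM with a range of 35000 nM to 150000 nM.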

Compound 4, half-maximal effective concentration: 75000 nM
The estimate for compound 4 lay 1.0-fold (0.02 log units) below the measured number; measured number inside the range.
By their numbers in this assay, from the lowest: compounds 3, 2, 4 and 1 (each within the scatter of the next).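

The earlier steps shown here swapped one group on the ring for a different one, whereas this step keeps the same fluorine and only changes its place on the ring. Going from 2-fluorophenyl to 3-fluorophenyl in this assay gives a 1.0-fold higher number from compound 3 to compound 4 (0.02 log units; within the scatter) and so leaves the number at the same level, which means that these two fluorine placements cannot be told apart here. Nothing available explains this flatness. Still open, going by these compounds, is whether an amine or a carboxylic acid on this ring would shift the number away from this level.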